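The compounds below may be only part of what the source reports. "The series", "measured", "known", "first", "only" and "open" are said of these compounds alone.

Results in an ADME assay on the whole organism (plasma, strain Sprague-Dawley) for pharmacokinetics, with Rattus norvegicus as the target, read by LC-MS, at a dose of 10 mg/kg by the oral route; on this read-out lower numbers stand for lower exposure and higher numbers for higher exposure at the dose given:
- compound 1 `CC(C)(C)c1cc(NC(=O)Nc2ccc(NC(=O)c3ccc(OC4CCN(C(C)(C)C)CC4)cn3)cc2)no1`: 2670 ng.h/mL
- compound 2 `CC(C)(C)c1cc(NC(=O)Nc2ccc(NC(=O)c3ccc(OC4CCNCC4)cn3)cc2)no1`: 766 ng.h/mL
- compound 3 `CCN1CCC(Oc2ccnc(C(=O)Nc3ccc(NC(=O)Nc4cc(C(C)(C)C)on4)cc3)c2)CC1`: "not determined" (no result reported)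

Compound 2 gives 766 ng.h/mL in this assay, the lower of the two numbers available, and compound 1 gives the other. Compound 4 `CC1(C)CC(Oc2ccc(C(=O)Nc3ccc(NC(=O)Nc4cc(C(C)(C)C)on4)cc3)nc2)CC(C)(C)N1` is still unmeasured and differs from compound 2 as follows: 2,2,6,6-tetramethylpiperidin-4-yl in place of piperidin-4-yl on an oxygen on an aromatic ring. Within the data shown here, only one measured step bears on this change, a 3.5-fold lower number from compound 1 to compound 2 (0.54 log units; beyond the scatter), a modest step beyond the scatter. That step has hydrogen in place of tert-butyl on an amine nitrogen in a ring, so it is a related change and not the same one. It suggests a higher number for the more substituted ring, of similar or smaller size. The expected step is a 2.0-fold higher number from compound 2 to compound 4 (0.29 log units; within the scatter). For compound 4 the estimate is 1500 ng.h/mL, with an expected range from 500 ng.h/mL to 4500 ng.h/mL.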

Compound 4, area under the concentration-time curve: 1280 ng.h/mL
The estimate for compound 4 lay 1.2-fold (0.07 log units) above the measured number; low and high end bracket the measured number.
By their numbers in this assay, from the lowest: compounds 2 and 4 (each within the scatter of the next); then compound 1.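

In this assay, putting 2,2,6,6-tetramethylpiperidin-4-yl in place of piperidin-4-yl on the oxygen gives a 1.7-fold higher number from compound 2 to compound 4 (0.22 log units; within the scatter) and so does not separate the two groups. Replacing 1-(tert-butyl)piperidin-4-yl with 2,2,6,6-tetramethylpiperidin-4-yl gives a 2.1-fold lower number from compound 1 to compound 4 (0.32 log units; beyond the scatter) and shows that added carbon on the ring alone does not match the exposure seen with the 1-(tert-butyl) group. Nothing available explains this difference. From the compounds shown here alone, whether a methyl or ethyl group on the ring nitrogen of the 2,2,6,6-tetramethylpiperidin-4-yl group would change the number remains open. So does the outcome with an open-chain amine in place of the ring.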